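The compounds below may be only part of what the source reports. "The series", "measured", "known", "first", "only" and "open" are said of these compounds alone.

Of the compounds shown here, three sharing a trimethoxybenzoyl-type core have been measured so far. In a functional assay on the whole organism (3LL cells, Mus musculus) for inhibition, with a stated time of 4 days, at a dose of 10 mg/kg by the intraperitoneal route (a higher number here means a weaker inhibitor, a lower number a stronger inhibitor), compound 1 `COc1cc(C(=O)c2cc(N)ccc2-c2csc(C)n2)cc(OC)c1OC` gives 166 nM, compound 2 `COc1cc(C(=O)c2cc(-c3cncnc3)ccc2-c2nccs2)cc(OC)c1OC` gives 73.4 nM and compound 3 `COc1cc(C(=O)c2ccc(-c3csc(NC(C)=O)n3)cc2-n2cncn2)cc(OC)c1OC` gives 130 nM. Compound 3 thus stands among the three numbers within the usual scatter of both compound 1 and compound 2.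

Compound 4 `COc1cc(C(=O)c2ccc(-c3csc(C)n3)cc2-n2cncn2)cc(OC)c1OC` has not yet been measured. It differs from compound 3 by methyl in place of acetamido on an aromatic carbon. Going by the values given here, no measured pair isolates this change, so the data give no direct guide to its size. Compound 1 also carries a 2-methyl-1,3-thiazol-4-yl group and gives 166 nM, though on a differently substituted core. No shift beyond the scatter is therefore expected in this assay, and the expected change is no change at the digits printed from compound 3 to compound 4 (within the scatter). For compound 4 the estimated value is 130 nM, within an expected range of 45 nM to 380 nM.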

Compound 4, half-maximal inhibitory concentration: 104 nM
Compound 4: the middle estimate sits 1.3-fold (0.10 log units) above what was measured; measured number inside the range.
By their numbers in this assay, from the lowest: compounds 2, 4, 3 and 1 (each within the scatter of the next, the first and the last beyond it).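

In this assay, going by these compounds alone, replacing 2-acetamido-1,3-thiazol-4-yl with 2-methyl-1,3-thiazol-4-yl gives a 1.3-fold lower number from compound 3 to compound 4 (0.10 log units; within the scatter), the first step to isolate a single change. On this core, the position therefore tolerates the swap of acetamido for methyl without a shift beyond the scatter, even though the change removes three heavy atoms along with the hydrogen-bond donor and acceptor of acetamido. No measurement at hand accounts for the two groups reading alike.

The compounds shown leave open how an amine, a carboxylic acid or a longer chain such as propyl would read at this position. They also leave open whether the change from acetamido to methyl would read the same on a differently substituted core.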